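The compounds below may be only part of what the source reports. "The series", "measured", "known", "first", "only" and "open" are said of these compounds alone.

Working notes on the dithiocarbamate series built on the shared core of compound 1, `CCNC(=S)SCC1=CCOC1=O`. In a functional assay on HeLa cells (Homo sapiens) for antiproliferative activity, read by MTT assay, with a stated time of 72 h (on this read-out lower numbers stand for stronger inhibition and higher numbers for weaker inhibition), compound 1 gives "not active" (no number reported), so no number stands for it and there is no point on the scale from which a step can be counted. The two carriers of the same core that do carry numbers are compound 2, `Cc1ccc(NC(=S)SCC2=CCOC2=O)cc1`, which gives 5440 nM in this assay, and compound 3, `O=C1OCC=C1CSC(=S)NCc1ccccc1`, which gives 15100 nM in this assay. Both of these sit in the micromolar range.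

Compound 4, `CC(C)NC(=S)SCC1=CCOC1=O`, differs from compound 1 by methyl in place of hydrogen on a saturated chain carbon bound to an amide-type nitrogen and a saturated chain carbon. Among the compounds with values here, with compound 1 giving no number, no step in this assay can be measured for this change, and nothing among the measured compounds speaks for the added methyl moving the value out of the inactive region; the expected step is therefore none beyond the scatter, toward the same inactive outcome. Compound 4 is estimated at 60000 nM in this assay, with an expected range from 20000 nM to 200000 nM, and a real chance that only a limit is reported.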

Compound 4, half-maximal inhibitory concentration: 137000 nM
Beside the measured number, compound 4's estimate is 2.3-fold (0.36 log units) below it, within the range that was stated.
By their numbers in this assay, from the lowest: compound 2; then compound 3; then compound 4.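

No step can be read between compound 1 and compound 4, as compound 1 carries no number in this assay. The compounds shown leave open how far the change from ethyl to isopropyl shifts antiproliferative activity. No measurement shown here bears on this result.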